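Swapping the aniline ring on a thiazolopyrimidine antagonist

This account rests on a few compounds, and the source may have more. Where it says the series, first, only, none or still open, it means among the compounds named here.

Measured compounds:
Compound 1, `FC(F)(F)c1ccc(Nc2ncnc3sc(Nc4c(Cl)cccc4Cl)nc23)cc1`: 3 nM
Compound 2, `FC(F)(F)c1ccc(Nc2ncnc3sc(Nc4ccccc4C(F)(F)F)nc23)cc1`: 37 nM

For the measured compounds named here, in a functional assay on HEK293 cells for antagonist activity at transient receptor potential cation channel subfamily V member 1 (Rattus norvegicus), read by calcium flux (on this read-out higher numbers stand for weaker inhibition and lower numbers for stronger inhibition), compound 2 gives the higher of the two numbers, and its only neighbour is compound 1, whose number is lower. Going by the values given here, the one measured step bears directly on the next change: a 12-fold higher number from compound 1 to compound 2 (1.09 log units; beyond the scatter). Compound 3, `N#Cc1cc(Cl)c(Nc2nc3c(Nc4ccc(C(F)(F)F)cc4)ncnc3s2)c(Cl)c1`, reverses that move and adds a nitrile: 2,6-dichloro-4-cyanophenyl in place of 2-(trifluoromethyl)phenyl on a nitrogen on an aromatic ring. As far as these compounds go, the 2,6-dichloro pattern of compound 1 is thus restored, while the nitrile is untested. Compound 3 is therefore expected to move by a 7.4-fold lower number from compound 2 to compound 3 (0.87 log units; beyond the scatter), landing near compound 1, with an estimate of 5 nM (range 1.5 nM to 20 nM).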

Compound 3, half-maximal inhibitory concentration: 53 nM
Beside the measured number, compound 3's estimate is 11-fold (1.03 log units) below it; measured number outside the range, above it.
By their numbers in this assay, from the lowest: compound 1; then compounds 2 and 3 (each within the scatter of the next).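

In this assay, the 2,6-dichloro pattern alone does not secure strong inhibition: cyano in place of hydrogen on an aromatic carbon gives an 18-fold higher number from compound 1 to compound 3 (1.25 log units; beyond the scatter) and removes the advantage compound 1 held. Set against 2-(trifluoromethyl)phenyl, the 2,6-dichloro-4-cyanophenyl group gives a 1.4-fold higher number from compound 2 to compound 3 (0.16 log units; within the scatter), so these two groups cannot be told apart here. Nothing available explains the cost of adding the nitrile.

As far as these compounds go, whether that cost belongs to the nitrile or to any group on that carbon stays open. Fluorine, a methyl group or a methoxy group there would help to separate the two.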